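The source may report more compounds than this note shows. Statements on the series, on what has been measured and on what is new or still open speak of the compounds shown alone.

Two compounds have so far been measured in a functional assay on WI-38 VA13 cells (Homo sapiens) for cytotoxicity; on this read-out lower numbers stand for an effect already at smaller amounts and higher numbers for an effect only at larger amounts of compound:

compound 1 `Cc1[nH][n+](C)c(C)c1C(=O)Nc1ccc2nc(NC(=O)C3CCCCC3)sc2c1` gives 0.012 ug/mL
compound 2 `CCCCCCCC(=O)Nc1nc2ccc(NC(=O)c3c(Cl)cccc3Cl)cc2s1` gives 0.18 ug/mL

Of these two numbers, compound 2 stands at the higher one in this assay. Its nearest neighbour is compound 1, which gives the lower number, and the gap between the two lies beyond the usual scatter of repeated measurements. Among the measured compounds shown here, no step between compounds that differ in a single place has been recorded, so the two values show only that these two compounds, which differ in more than one place, separate clearly.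

Compound 3 `CC(C)(C)OC(=O)Nc1nc2ccc(NC(=O)c3c(Cl)cccc3Cl)cc2s1` has not yet been measured. It differs from compound 2 in one place: tert-butoxy in place of heptyl on a carbonyl carbon. Nothing among the measured compounds follows a change of this kind, so the size of the step cannot be read from a shown example. The expectation here is a small step of a 1.7-fold higher number from compound 2 to compound 3 (0.22 log units; within the scatter), most likely not beyond the scatter and, if anything, towards a higher number. Compound 3 is therefore expected at 0.3 ug/mL, with a range from 0.06 ug/mL to 1.5 ug/mL.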

Compound 3, half-maximal effective concentration: 0.027 ug/mL
For compound 3 the middle estimate is 11-fold (1.05 log units) above the measured one; measured number outside the range, below it.
By their numbers in this assay, from the lowest: compound 1; then compound 3; then compound 2.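

In this assay, putting tert-butoxy in place of heptyl on a carbonyl carbon whose other neighbour is an amide-type nitrogen gives a 6.7-fold lower number from compound 2 to compound 3 (0.82 log units; beyond the scatter) and is the first change at a single place among these compounds. It shows that the group at this position can by itself move the number beyond the scatter, with the rest of compound 2 left unchanged, and that the 7 carbons of heptyl are not required for a number this low. The data at hand offer no explanation for the direction or the size of this step.

This single step changes the group's size, branching and oxygen content together, so it cannot show which of these differences matters, and a butyl group or an unbranched butoxy group on the same carbonyl carbon would be needed to separate them. It also leaves open whether the step carries over to other parts of the series, for example whether a tert-butylamino group at this position would behave like tert-butoxy, or whether the same exchange would go the same way with a different group on the other amide.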